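Moving the Hydroxymethyl Group on the Benzyl Arm

The compounds below may be only part of what the source reports. "The series", "measured", "known", "first", "only" and "open" are said of these compounds alone.

Compound 1 `Cc1c(C)c2ccc(OCC3CCN(Cc4cccc(CO)c4)CC3)cc2oc1=O` and compound 2 `Cc1cc2ccc(OCC3CCN(Cc4ccc(CO)cc4)CC3)cc2oc1=O` share a core linked through an ether chain to a ring-bound amine that carries a benzyl group bearing a hydroxymethyl substituent. In an assay for inhibition of Amine oxidase [flavin-containing] B (Homo sapiens), read by fluorescence, using microsomes, with a stated time of 30 min (on this read-out higher numbers stand for weaker inhibition and lower numbers for stronger inhibition), compound 1 gives 76 nM, while compound 2 gives 3100 nM. Compound 2 therefore stands at the higher of the two numbers, the weaker inhibitor, and its gap to compound 1 lies beyond the scatter. The two compounds differ in two places at once, a methyl on the core present only in compound 1 and the way the hydroxymethyl group is attached to the benzyl ring, so no single change is isolated by a measured step.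

Compound 3 `Cc1cc2ccc(OCC3CCN(Cc4cccc(CO)c4)CC3)cc2oc1=O` changes only one of these: 3-(hydroxymethyl)phenyl in place of 4-(hydroxymethyl)phenyl on a saturated chain carbon bound to an amine nitrogen in a ring. Compound 3 thus differs from compound 1 solely by the core methyl. Because compound 1 reaches 76 nM, the step from compound 2 to compound 3 is expected to lower the number beyond the scatter, though perhaps not the whole way, as in a 10-fold lower number from compound 2 to compound 3 (1.01 log units; beyond the scatter). For compound 3 the estimate is 300 nM, within a range of 70 nM to 1500 nM.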

Compound 3, half-maximal inhibitory concentration: 1100 nM
Estimate against measurement, compound 3: 3.7-fold (0.56 log units) below, and the stated range covers the measured number.
By their numbers in this assay, from the lowest: compound 1; then compound 3; then compound 2.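

In this assay, 3-(hydroxymethyl)phenyl in place of 4-(hydroxymethyl)phenyl on a saturated chain carbon bound to an amine nitrogen in a ring gives a 2.8-fold lower number from compound 2 to compound 3 (0.45 log units; beyond the scatter), so moving the hydroxymethyl group around the benzyl ring alone has a real but modest effect on this read-out. The same compound also isolates the core methyl for the first time: hydrogen in place of methyl on an aromatic carbon gives a 14-fold higher number from compound 1 to compound 3 (1.16 log units; beyond the scatter), a large step, and among these three compounds this single methyl accounts for the bigger of the two changes. No measured evidence is available here to explain why either change alters inhibition.

On these data alone, the effect of 4-(hydroxymethyl)phenyl on the core of compound 1 remains open, so these three compounds cannot tell whether the two steps simply add together or depend on each other. As far as these compounds go, it is also open how a different group, such as a carboxylic acid or an amine, would compare with the hydroxymethyl group on the benzyl ring, or how a longer chain ending in a hydroxyl would behave in its place.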